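Swapping a Five-Membered Ring for Pyridine in a CXCR3 Series

A few compounds are considered here, and "the series" means these few. Any claim that something is new, unique, unknown or untested is made for them only; others in the source may bear on it.

Of the compounds shown here, three sharing one core have been tested in a functional assay for antagonist activity at C-X-C chemokine receptor type 3 (Homo sapiens); on this read-out lower numbers stand for stronger inhibition and higher numbers for weaker inhibition. Compound 1 `CNC(=O)c1cnc(N2CCN(C3CCN(Cc4ccco4)CC3)[C@@H](C)C2)c(Cl)c1` gives 8100 nM. Compound 2 `CNC(=O)c1cnc(N2CCN(C3CCN(Cc4cccs4)CC3)[C@@H](C)C2)c(Cl)c1` gives 1980 nM. Compound 3 `CNC(=O)c1cnc(N2CCN(C3CCN(Cc4ccc[nH]4)CC3)[C@@H](C)C2)c(Cl)c1` gives 8060 nM, which places it second highest of the three numbers; the steps reaching it from the other two are a 1.0-fold lower number from compound 1 to compound 3 (0.00 log units; within the scatter) and a 4.1-fold higher number from compound 2 to compound 3 (0.61 log units; beyond the scatter).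

Compound 4 `CNC(=O)c1cnc(N2CCN(C3CCN(Cc4ccccn4)CC3)[C@@H](C)C2)c(Cl)c1` has not yet been measured. It differs from compound 3 in one place: pyridin-2-yl in place of 1H-pyrrol-2-yl on a saturated chain carbon bound to an amine nitrogen in a ring.

For the measured compounds named here, none of the measured steps covers a six-membered ring at this position. Going by the values given here, the steps of a 4.1-fold lower number from compound 1 to compound 2 (0.61 log units; beyond the scatter) and a 4.1-fold higher number from compound 2 to compound 3 (0.61 log units; beyond the scatter) show only that exchanging one five-membered ring for another can shift this assay modestly or not at all. Because compound 3 sits at 8060 nM and the nearest comparison, compound 1, sits within the scatter of it, the expectation is a step of a 1.6-fold lower number from compound 3 to compound 4 (0.21 log units; within the scatter), perhaps a small improvement, but possibly nothing beyond the scatter. Compound 4 is therefore expected to give about 5000 nM, with a range from 1500 nM to 16000 nM.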

Compound 4, half-maximal inhibitory concentration: 7990 nM
The estimate for compound 4 lay 1.6-fold (0.20 log units) below the measured number, within the range that was stated.
By their numbers in this assay, from the lowest: compound 2; then compounds 4, 3 and 1 (each within the scatter of the next).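

In this assay, a six-membered ring can now be read on a saturated chain carbon bound to an amine nitrogen in a ring, and pyridin-2-yl gives no separation from 1H-pyrrol-2-yl (a 1.0-fold lower number from compound 3 to compound 4 (0.00 log units; within the scatter)) or from furan-2-yl (a 1.0-fold lower number from compound 1 to compound 4 (0.01 log units; within the scatter)). Thiophen-2-yl alone stands apart (a 4.0-fold higher number from compound 2 to compound 4 (0.61 log units; beyond the scatter)), so in these four compounds neither the larger ring nor the exchange of a hydrogen-bond donor for an acceptor from compound 3 to compound 4 moves the number beyond the scatter. No measurement here explains why thiophen-2-yl differs from the other three groups.

As far as these compounds go, whether a phenyl ring, a thiazol-2-yl ring or a longer chain carrying thiophen-2-yl would match or pass compound 2 remains open. From the compounds shown here alone, all four compounds share one core, so it is also open whether the same pattern holds on any other core.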